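The compounds below may be only part of what the source reports. "The series", "measured", "known", "first", "only" and "open" are said of these compounds alone.

The measured compounds are compound 1 `C=C[C@@](C)(/C=C/c1ccc(Nc2ccccc2)cc1)CCC=C(C)C`, compound 2 `C=C[C@@](C)(/C=C/c1ccc(Nc2ccc(OC(F)(F)F)cc2)cc1)CCC=C(C)C` and compound 3 `C=C[C@@](C)(/C=C/c1ccc(Nc2cccc(C(F)(F)F)c2)cc1)CCC=C(C)C`.

In a functional assay on HepG2 cells (Homo sapiens) for cytotoxicity, with a stated time of 72 h (a higher number here means that more compound is needed for the effect, a lower number that less compound is needed), compound 1 reaches only the assay limit, > 52000 nM, and not a number. Compound 2 likewise gives only the assay limit, > 52000 nM. Compound 3 also stops at the assay limit, > 52000 nM. Compound 1 therefore stands at a limit rather than at a number, and the same holds for the other two values (the limit of > 52000 nM in this assay, at which 3 of the 3 values shown sit). The steps a step that the two limits leave unreadable from compound 1 to compound 2 and a step that the two limits leave unreadable from compound 1 to compound 3 cannot be read in size or direction, as both ends of each sit at the limit.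

Compound 4 `C=C[C@@](C)(/C=C/c1ccc(-c2ccc(Cl)c(Cl)c2)cc1)CCC=C(C)C` differs from compound 1 as follows: 3,4-dichlorophenyl in place of anilino on an aromatic carbon. Among the compounds with values here, no measured step bears on this exchange, and the two steps that start from compound 1 are both unreadable, so they give no direction to expect. The plain expectation is that compound 4 also comes out at the limit. Compound 4 is accordingly estimated at 52000 nM, with a range from 20000 nM to 120000 nM. This estimate means a step of a number no higher from compound 1 to compound 4 (the limit leaves the size open), which is expected to be none beyond the scatter.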

Compound 4, half-maximal effective concentration: > 52000 nM
Compound 4: only a limit was reported; the forecaster's own chance of this, stated with the estimate: 70%; the middle value sits exactly at the limit.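

In this assay compound 4 gives only a limit, > 52000 nM, and not a number. The step between compound 1 and compound 4 therefore cannot be read in size or direction: the limit of > 52000 nM in this assay, at which 4 of the 4 values shown sit.

The compounds shown leave open how these exchanged groups would compare if a value fell inside the range of this assay.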